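Adding a methyl group beside the phenoxy linker

The source may report more compounds than this note shows. Statements on the series, on what has been measured and on what is new or still open speak of the compounds shown alone.

Measured so far:
Compound 1, `CCOC(=O)c1cc2c(n1CC)C(=O)C(Oc1ccc(Cl)cc1)=CC2=O`: "not determined" (no result reported).
Compound 2, `CCOC(=O)c1cc2c(n1CC)C(=O)C(Oc1ccccc1)=CC2=O`: 22000 nM.

Within the data shown here, in an ADME assay on J774 cells (Mus musculus) for cytotoxicity, read by MTT assay, with a stated time of 48 h (a higher number here means a weaker inhibitor, a lower number a stronger inhibitor), compound 2 gives 22000 nM, the only number in this set, so it stands alone. Compound 3, `CCOC(=O)c1cc2c(n1CC)C(=O)C(Oc1ccccc1C)=CC2=O`, is not yet measured. It differs from compound 2 by methyl in place of hydrogen on an aromatic carbon. Among the measured compounds shown here, with no measured step to lean on, the step from compound 2 to compound 3 is expected to stay within the usual scatter, a 1.1-fold lower number from compound 2 to compound 3 (0.04 log units; within the scatter). Compound 3 is therefore estimated at 20000 nM, between 8000 nM and 50000 nM.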

Compound 3, half-maximal inhibitory concentration: 12500 nM
Beside the measured number, compound 3's estimate is 1.6-fold (0.20 log units) above it; low and high end bracket the measured number.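

Among these compounds, this is the first measured change on the phenoxy ring: in this assay, swapping phenoxy for 2-methylphenoxy gives a 1.8-fold lower number from compound 2 to compound 3 (0.25 log units; within the scatter) and so does not clearly separate the two compounds. A methyl on this aromatic carbon, ortho to a large group, therefore leaves the cytotoxicity reading about where it was. Nothing available here accounts for the small difference. Still open, from the compounds shown here alone, is whether a bigger or different group at this place, such as a methoxy, an amine or a longer chain, would shift the number beyond the scatter.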